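The source may report more compounds than this note shows. Statements on the series, on what has been measured and on what is new or still open speak of the compounds shown alone.

The measured compounds and their numbers in a functional assay on HeLa cells (Homo sapiens) for cytotoxicity, read by MTT assay; a lower number here means a stronger inhibitor, a higher number a weaker inhibitor:

Compound 1, `CCC(C)(O)CC(=O)O[C@H](CC=C(C)C)C1=CC(=O)c2c(O)ccc(O)c2C1=O`: 25200 nM
Compound 2, `CC(C)=CC[C@@H](OC[C@@H](C)O)C1=CC(=O)c2c(O)ccc(O)c2C1=O`: 22500 nM
Compound 3, `CCCC(O)CC(=O)O[C@H](CC=C(C)C)C1=CC(=O)c2c(O)ccc(O)c2C1=O`: 59300 nM

Compound 3 stands at the highest number of the three, so it is the weakest inhibitor shown; the steps of a 2.4-fold higher number from compound 1 to compound 3 (0.37 log units; beyond the scatter) and a 2.6-fold higher number from compound 2 to compound 3 (0.42 log units; beyond the scatter) both lie beyond the scatter. The step from compound 3 to compound 4, `CCC(O)(CC)CC(=O)O[C@H](CC=C(C)C)C1=CC(=O)c2c(O)ccc(O)c2C1=O`, changes the group on the saturated chain carbon bound to the carbonyl carbon: 1-ethyl-1-hydroxypropyl in place of 1-hydroxybutyl on a saturated chain carbon bound to a carbonyl carbon. For the measured compounds named here, only one measured step touches the same place, a 2.4-fold higher number from compound 1 to compound 3 (0.37 log units; beyond the scatter), in which a 1-hydroxy-1-methylpropyl group was swapped for a 1-hydroxybutyl group and the number rose modestly. The change to compound 4 runs the other way, from a 1-hydroxybutyl group back to a group carrying a hydroxyl and two further carbons on the same carbon, 1-ethyl-1-hydroxypropyl, which resembles the group in compound 1 with one more carbon. A modest drop in the number is therefore expected, roughly the size of the rise seen in a 2.4-fold higher number from compound 1 to compound 3 (0.37 log units; beyond the scatter), so that compound 4 lands near compound 1. Compound 4 is estimated at 26000 nM, with a range from 12000 nM to 55000 nM, meaning an expected step of a 2.3-fold lower number from compound 3 to compound 4 (0.36 log units; beyond the scatter).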

Compound 4, half-maximal inhibitory concentration: 52000 nM
For compound 4 the middle estimate is 2.0-fold (0.30 log units) below the measured one; the range from low to high includes it.
By their numbers in this assay, from the lowest: compounds 2 and 1 (each within the scatter of the next); then compounds 4 and 3 (each within the scatter of the next).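

In this assay, replacing 1-hydroxybutyl with the branched 1-ethyl-1-hydroxypropyl gives a 1.1-fold lower number from compound 3 to compound 4 (0.06 log units; within the scatter), so at this saturated chain carbon bound to a carbonyl carbon, branching alone does not bring the number down to that of compound 1. The step of a 2.1-fold higher number from compound 1 to compound 4 (0.31 log units; beyond the scatter) shows that the small difference between 1-hydroxy-1-methylpropyl and 1-ethyl-1-hydroxypropyl is enough for a modest rise, which means that among these three groups only the one in compound 1 goes with the lower number. The step of a 2.3-fold higher number from compound 2 to compound 4 (0.36 log units; beyond the scatter) places compound 4 on the weaker side of the 2-hydroxypropyl compound too, leaving compounds 3 and 4 together as the pair with the higher numbers, while compounds 1 and 2 form the pair with the lower numbers.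

The data shown offer no measured explanation for why these closely related groups differ. Still open, as far as these compounds go, is how this place would respond to an amine in place of the hydroxyl, to a carboxylic acid, or to a longer chain than 1-ethyl-1-hydroxypropyl.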